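A few compounds are considered here, and "the series" means these few. Any claim that something is new, unique, unknown or untested is made for them only; others in the source may bear on it.

Of the compounds shown here, three have been measured: compound 1 `COc1cccc(OC)c1OCCNCCOc1ccccc1OCc1ccccc1`, compound 2 `COc1cccc(OC)c1OCCNCCOc1ccccc1OCc1ccc(Cl)cc1` and compound 3 `COc1cccc(OC)c1OCCNCCOc1ccccc1OCc1ccc([N+](=O)[O-])cc1`. In an assay on CHO cells for displacement of a labelled ligand from Alpha-1D adrenergic receptor (Homo sapiens) (on this read-out lower numbers stand for stronger inhibition and higher numbers for weaker inhibition), compound 1 gives 0.0676 nM, compound 2 gives 0.0316 nM and compound 3 gives 0.0501 nM. Compound 3 stands second highest of the three, and its steps to the other two are both within the scatter: a 1.3-fold lower number from compound 1 to compound 3 (0.13 log units; within the scatter) and a 1.6-fold higher number from compound 2 to compound 3 (0.20 log units; within the scatter). Compound 4 `COc1ccc(COc2ccccc2OCCNCCOc2c(OC)cccc2OC)cc1` has not yet been measured; it differs from compound 3 by methoxy in place of nitro on an aromatic carbon. Among the measured compounds shown here, no measured step involves a methoxy group, so the steps that bear on it are the two nitro steps and a 2.1-fold lower number from compound 1 to compound 2 (0.33 log units; beyond the scatter), the only one beyond the scatter. For the measured compounds named here, all changes made at this place so far have moved the number little. Compound 4 is expected to stay close, with a 1.0-fold lower number from compound 3 to compound 4 (0.00 log units; within the scatter). In this assay compound 4 is estimated at 0.05 nM, ranging from 0.02 nM to 0.13 nM.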

Compound 4, inhibition constant: 0.1 nM
For compound 4 the middle estimate is 2.0-fold (0.30 log units) below the measured one; the range from low to high includes it.
By their numbers in this assay, from the lowest: compounds 2, 3, 1 and 4 (each within the scatter of the next, the first and the last beyond it).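

Methoxy adds a second gap beyond the scatter at this position, namely a 3.2-fold higher number from compound 2 to compound 4 (0.50 log units; beyond the scatter) and, like the earlier gap, it involves the chloro group of compound 2. Methoxy cannot be told apart from nitro or from hydrogen here, as a 2.0-fold higher number from compound 3 to compound 4 (0.30 log units; within the scatter) and a 1.5-fold higher number from compound 1 to compound 4 (0.17 log units; within the scatter) both stay within the scatter. Nothing available gives a cause for these differences.

The compounds shown leave open how an amine, a carboxylic acid or a longer alkoxy chain would read at this position.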